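Nitro to Amino: What to Expect for Compound 4

The source may hold more compounds than are shown below. What is called first, only, known or untested is meant among the compounds shown, and "the series" means these compounds.

Compound 1 `COc1ccc(-c2ssc(=S)c2-c2cc(OC)c(OC)c(OC)c2)cc1[N+](=O)[O-]`: in a functional assay on KB cells (Homo sapiens) for antiproliferative activity, read by MTT assay, with a stated time of 72 h (on this read-out lower numbers stand for stronger inhibition and higher numbers for weaker inhibition), compound 1 reaches only a limit of the assay, > 100000 nM.
Compound 2 `COc1ccc(-c2ssc(=S)c2-c2cc(OC)c(OC)c(OC)c2)cc1N`: in this assay compound 2 gives 327 nM.
Compound 3 `COc1ccc(-c2ssc(=O)c2-c2cc(OC)c(OC)c(OC)c2)cc1[N+](=O)[O-]`: in this assay compound 3 gives 22300 nM.

Compound 4 `COc1ccc(-c2ssc(=O)c2-c2cc(OC)c(OC)c(OC)c2)cc1N` has not yet been measured. Among the measured pair with a counted step, the change amino in place of nitro on an aromatic carbon produced an at least 300-fold lower number from compound 1 to compound 2 (2.48 log units; beyond the scatter). Because the value of compound 1 sits at the limit of > 100000 nM in this assay, at which 1 of the 3 values shown sits, this step is only a lower bound on its true size. Compound 3 holds the higher of the two numbers given, well apart from compound 2. How the core of compound 3 differs from the core of compound 1 is not broken down here. The change from compound 3 to compound 4, (amino in place of nitro on an aromatic carbon), is the same change, at a place described in the same words. Compound 4 is therefore expected to show a large step, a 220-fold lower number from compound 3 to compound 4 (2.35 log units; beyond the scatter), an expectation resting on an at least 300-fold lower number from compound 1 to compound 2 (2.48 log units; beyond the scatter) together with the starting point of compound 3 at 22300 nM. Compound 4 is estimated at 100 nM, expected to fall between 20 nM and 600 nM.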

Compound 4, half-maximal inhibitory concentration: 60 nM
Compound 4: middle estimate off by 1.7-fold (0.22 log units), on the high side; the measured number falls inside the stated range.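

In this assay, amino in place of nitro on an aromatic carbon again gave a large drop, a 370-fold lower number from compound 3 to compound 4 (2.57 log units; beyond the scatter), so the change carried from the core of compound 1 to the core of compound 3 in the same direction. Set side by side, the two steps read: the same change on two cores in this assay, an at least 300-fold lower number (2.48 log units; beyond the scatter) from compound 1 to compound 2 and a 370-fold lower number (2.57 log units; beyond the scatter) from compound 3 to compound 4; the limit leaves it open whether they differ. This shows a shared direction and a large step on both cores, but it does not fix how closely the two sizes agree, and two cores alone say nothing about any other core in this series; the first step starts from a limit and not from a number: the limit of > 100000 nM in this assay, at which 1 of the 4 values shown sits.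

The compounds shown carry only nitro or amino at this place, so it remains open how a hydroxyl group, a methylamino group or an acetamide would read there. As far as these compounds go, it also remains open whether the step would hold if an ethoxy group stood in place of the methoxy group to which the amino group is ortho.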